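The source may hold more compounds than are shown below. What is called first, only, known or untested is meant among the compounds shown, and "the series" means these compounds.

Compound 1 `O=C(CSc1ncccn1)N/N=c1/scc(-c2ccc(Br)cc2)n1-c1ccccc1`, compound 2 `Cc1ccc(-c2cs/c(=N/NC(=O)CSc3ncccn3)n2-c2ccccc2)cc1` and compound 3 `Cc1nnc(SCC(=O)N/N=c2/scc(-c3ccc(Br)cc3)n2-c2ccccc2)s1` were run in a functional assay on C6 cells (Rattus norvegicus) for cytotoxicity, read by MTT assay, with a stated time of 24 h; on this read-out lower numbers stand for stronger inhibition and higher numbers for weaker inhibition. In this assay compound 1 gives > 200 ug/mL, which is a limit of the assay and not a number. In this assay compound 2 gives 85 ug/mL. For compound 3 the result in this assay is "not determined" (no result reported), so no result was reported. Compound 4 `Cc1ccc(-c2cs/c(=N/NC(=O)CSc3nnc(C)s3)n2-c2ccccc2)cc1` has not yet been measured.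

Compound 1 and compound 2 differ in one place: methyl in place of bromo on an aromatic carbon This change gives an at least 2.3-fold lower number from compound 1 to compound 2 (0.37 log units; beyond the scatter). The step can only be given as a bound because compound 1 sits at the limit of > 200 ug/mL in this assay, at which 1 of the 3 values shown sits.

The core of compound 3 differs from the core of compound 1 in this way: 5-methyl-1,3,4-thiadiazol-2-yl in place of pyrimidin-2-yl on a sulfur

Compound 4 stands to compound 3 as compound 2 stands to compound 1, the same kind of change: methyl in place of bromo on an aromatic carbon The surroundings of the place are described in the same words for both pairs.

Among the measured compounds shown here, since compound 3 has no number, no step from compound 3 to compound 4 can be counted. The expectation for compound 4 rests on compound 2, which gives 85 ug/mL in this assay, and on the size of an at least 2.3-fold lower number from compound 1 to compound 2 (0.37 log units; beyond the scatter). Compound 4 is expected to give about 80 ug/mL. The estimate for compound 4 is expected to lie between 30 ug/mL and 200 ug/mL.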

Compound 4, half-maximal inhibitory concentration: 25.3 ug/mL
Beside the measured number, compound 4's estimate is 3.2-fold (0.50 log units) above it, and the stated range ends above it.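

In this assay, putting 5-methyl-1,3,4-thiadiazol-2-yl in place of pyrimidin-2-yl on the sulfur gives a 3.4-fold lower number from compound 2 to compound 4 (0.53 log units; beyond the scatter), so on the core that carries 4-methylphenyl this swap goes with stronger inhibition. Whether the same swap does the same on the core that carries 4-bromophenyl cannot be read, and neither can the change from bromo to methyl on the thiadiazolyl side of the series, as compound 3 has no result and the steps that involve it have no size. Among the compounds shown here, compound 1 gives > 200 ug/mL, which is a limit of the assay and not a number, so the one comparison of bromo with methyl stays a bound and the swap on the sulfur rests on a single pair.

The compounds shown leave open how an amine or a carboxylic acid in place of the methyl on the six-membered aromatic ring would read. Also open, on these data alone, is whether compound 4 would behave alike on cells other than C6 cells.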